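Methoxy for Methyl on a Shared Anticonvulsant Core

This account rests on a few compounds, and the source may have more. Where it says the series, first, only, none or still open, it means among the compounds named here.

Measured so far:
- compound 1, `COc1ccc(Nc2nnc(Nc3nc(-c4ccc(Br)cc4)cs3)s2)cc1`: 30 mg/kg
- compound 2, `Cc1ccc(Nc2nnc(Nc3nc(-c4ccccc4)cs3)s2)cc1`: 100 mg/kg

Of the compounds shown here, two built on the same core have been tested in a functional assay on the whole organism (strain albino) with Mus musculus as the target, in the maximal electroshock model, with a stated time of 0.5 h; on this read-out higher numbers stand for an effect only at larger amounts of compound and lower numbers for an effect already at smaller amounts. Compound 1 gives 30 mg/kg. Compound 2 gives 100 mg/kg, the highest of the two numbers, and its nearest neighbour is compound 1, whose number is lower by an amount beyond the usual scatter. Compound 1 and compound 2 differ in two places at once, so the two values cannot be attributed to either change alone.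

Compound 3, `COc1ccc(Nc2nnc(Nc3nc(-c4ccccc4)cs3)s2)cc1`, has not yet been measured. It differs from compound 2 in one place: methoxy in place of methyl on an aromatic carbon. Among the measured compounds shown here, no single-change step between measured compounds exists here, so the expectation rests on the values of compound 1 and compound 2 alone.

Compound 3 is expected to show a modest step toward lower numbers, because compound 1, which also carries the methoxy group, gives 30 mg/kg. The expected step from compound 2 is a 1.8-fold lower number from compound 2 to compound 3 (0.26 log units; within the scatter). For compound 3 the estimate in this assay is 55 mg/kg, within a range from 25 mg/kg to 120 mg/kg.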

Compound 3, minimum effective dose: 100 mg/kg
Compound 3: middle estimate off by 1.8-fold (0.26 log units), on the low side; the range from low to high includes it.
By their numbers in this assay, from the lowest: compound 1; then compounds 2 and 3 (each within the scatter of the next).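

In this assay, the change from 4-methylphenyl to 4-methoxyphenyl now stands alone on the shared core, and the reading is no change at the digits printed from compound 2 to compound 3 (within the scatter), so on this evidence the two groups cannot be told apart at this position when no bromo is present elsewhere in the molecule. Among the compounds shown here, the lower number of compound 1 therefore finds its only single-place comparison in a different part of the structure, where hydrogen in place of bromo on an aromatic carbon gives a 3.3-fold higher number from compound 1 to compound 3 (0.52 log units; beyond the scatter), a step that compound 1 and compound 2 could not show, since they differ in two places at once. Nothing available explains why the bromo matters here and the methoxy does not.

From the compounds shown here alone, whether methyl and methoxy would also read alike in a compound that keeps the bromo remains open, so the two changes cannot yet be said to act independently of each other. Going by these compounds, it is also open what chloro or an amine would give in place of the bromo, and what a longer chain such as ethoxy would give in place of the methoxy.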